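Replacing bromine with a long chain on the shared core

The compounds below may be only part of what the source reports. "The series", "measured", "known", "first", "only" and "open" are said of these compounds alone.

Measured in a physicochemical assay for lipophilicity, at pH 7.4; a lower number here means a more polar compound, a higher number a more lipophilic compound:
compound 1 `CCc1c(C)[nH]c2cc(OC)c(Cl)cc2c1=O`: 2.43
compound 2 `COc1cc2[nH]c(C)c(C)c(=O)c2cc1Cl`: 1.86
compound 3 `COc1cc2[nH]c(C)c(Br)c(=O)c2cc1Cl`: 0

Compound 3 stands lowest of the three, and the other two lie beyond the scatter above it. The change to compound 4 `C=C(CCCCC)c1c(C)[nH]c2cc(OC)c(Cl)cc2c1=O` is a group of 7 heavy atoms (7 carbon; no ring) in place of one bromine atom, on an aromatic carbon: a group of 7 heavy atoms in place of one bromine atom, on an aromatic carbon.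

Among the measured compounds shown here, three measured steps bear on this change. Bromo in place of methyl gave a number 1.86 log units lower from compound 2 to compound 3 (beyond the scatter), and bromo in place of ethyl gave a number 2.43 log units lower from compound 1 to compound 3 (beyond the scatter). Both are large, and the new change runs the opposite way, with bromo leaving. Hydrogen in place of methyl on the chain gave a number 0.57 log units lower from compound 1 to compound 2 (beyond the scatter), a modest step and the only measure of chain length here. For the measured compounds named here, no measured compound has a double bond outside the aromatic rings, so the range stays wide.

Reversing the large step and adding further modest ones points to a large rise in this assay. The expected change is a number 4.60 log units higher from compound 3 to compound 4 (beyond the scatter). For compound 4 the estimate is 4.6, within an expected range of 3.8 to 5.4.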

Compound 4, distribution coefficient: 3.58
Compound 4: the middle estimate sits 1.02 log units above what was measured; the measured number lies below the stated range.
By their numbers in this assay, from the lowest: compound 3; then compound 2; then compound 1; then compound 4.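

In this assay, the group of 7 heavy atoms on this aromatic carbon puts compound 4 highest of the four, with a number 3.58 log units higher from compound 3 to compound 4 (beyond the scatter), a number 1.72 log units higher from compound 2 to compound 4 (beyond the scatter) and a number 1.15 log units higher from compound 1 to compound 4 (beyond the scatter). The earlier compounds reached only as far as ethyl at this position, and the number now proves still to climb with a carbon group much larger than ethyl; among the carbon groups shown, no compound goes against that order. Nothing available accounts for the size of these steps.

The compounds shown leave open how much of the rise belongs to the chain length and how much to the double bond outside the aromatic rings, which a saturated chain of the same carbon count would separate. They also leave open how a chain ending in an amine or a carboxylic acid would stand at this position.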